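The compounds below may be only part of what the source reports. "The series", "measured", "known", "first", "only" and "open" are said of these compounds alone.

In an ADME assay on Vero cells (Chlorocebus sabaeus) for cytotoxicity, read by resazurin assay, with a stated time of 72 h (on this read-out lower numbers stand for stronger inhibition and higher numbers for weaker inhibition), three compounds of one series have been measured. Compound 1 `O=C(CCN1CCN(c2ccc(F)cc2)CC1)c1ccc(Br)cc1` gives 99500 nM. Compound 2 `O=C(CCN1CCN(c2ccc(C(F)(F)F)cc2)CC1)c1ccc(Br)cc1` gives 78800 nM in this assay; it differs from compound 1 by trifluoromethyl in place of fluoro on an aromatic carbon, and this gave a 1.3-fold lower number from compound 1 to compound 2 (0.10 log units; within the scatter). Compound 3 `O=C(CCN1CCN(c2ccc(F)cc2)CC1)c1ccc(F)c(Br)c1` gives 352000 nM in this assay, the highest number of the three; the core of compound 3 differs from the core of compound 1 by 3-bromo-4-fluorophenyl in place of 4-bromophenyl on a carbonyl carbon, and this gave a 3.5-fold higher number from compound 1 to compound 3 (0.55 log units; beyond the scatter).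

Compound 4 `O=C(CCN1CCN(c2ccc(C(F)(F)F)cc2)CC1)c1ccc(F)c(Br)c1` has not yet been measured in this assay. It differs from compound 3 by trifluoromethyl in place of fluoro on an aromatic carbon. This is the same change as that made from compound 1 to compound 2, and it occurs twice among these compounds. The expectation for compound 4 rests on that earlier step: because a 1.3-fold lower number from compound 1 to compound 2 (0.10 log units; within the scatter) was within the scatter, compound 4 is expected to show a 1.3-fold lower number from compound 3 to compound 4 (0.12 log units; within the scatter), a step of about the same size. In this assay compound 4 is therefore estimated at 270000 nM, with a range from 130000 nM to 560000 nM.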

Compound 4, half-maximal inhibitory concentration: 66800 nM
For compound 4 the middle estimate is 4.0-fold (0.61 log units) above the measured one; measured number below the stated range.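

In this assay, trifluoromethyl in place of fluoro on an aromatic carbon gave a 5.3-fold lower number from compound 3 to compound 4 (0.72 log units; beyond the scatter), so the step seen on the core of compound 1 did not carry over at the same size to the core of compound 3: the same change on two cores in this assay, a 1.3-fold lower number (0.10 log units; within the scatter) from compound 1 to compound 2 and a 5.3-fold lower number (0.72 log units; beyond the scatter) from compound 3 to compound 4, 4.2-fold (0.62 log units) apart, beyond the scatter of two such steps. Read the other way, 3-bromo-4-fluorophenyl in place of 4-bromophenyl on a carbonyl carbon gave a 1.2-fold lower number from compound 2 to compound 4 (0.07 log units; within the scatter), so that change also depended on the core that carried it: the same change on two cores in this assay, a 3.5-fold higher number (0.55 log units; beyond the scatter) from compound 1 to compound 3 and a 1.2-fold lower number (0.07 log units; within the scatter) from compound 2 to compound 4, 4.2-fold (0.62 log units) apart, beyond the scatter of two such steps. Within these four compounds, the size of each change therefore depends on the other, but this rests on a single pair of steps for each change and shows neither the reason for the difference nor whether it holds for any other compound.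

The compounds shown leave open whether a nitrile or a methoxy group in place of trifluoromethyl would behave in the same way on these two cores. They also leave open what a longer chain on the carbonyl carbon would do to either step.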